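The compounds below may be only part of what the source reports. "The series", "measured", "known", "first", "only" and "open" are said of these compounds alone.

Compound 1 `COc1ccc(NC(=O)c2cccc(/C=C3\CC(=O)N(c4ccccc4)C3=O)c2)cc1` was tested in an ADME assay on HCT-116 cells (Homo sapiens) for cytotoxicity, read by MTT assay, with a stated time of 72 h (a higher number here means a weaker inhibitor, a lower number a stronger inhibitor), and gives only a limit there, > 100000 nM. Compound 2 `COc1ccc(NC(=O)c2cccc(/C=C3\CC(=O)N(c4ccc(C)cc4)C3=O)c2)cc1` also reaches only a limit in this assay, > 100000 nM. Compound 3 `CCCCCN1C(=O)C/C(=C\c2cccc(C(=O)Nc3ccc(OC)cc3)c2)C1=O` likewise stops at a limit in this assay, > 100000 nM. The change from compound 1 to compound 2 is a methyl in place of hydrogen on an aromatic carbon, and the step is a step that the two limits leave unreadable from compound 1 to compound 2. From compound 1 to compound 3 the change is pentyl in place of phenyl on an amide-type nitrogen in a ring, with the step that the two limits leave unreadable from compound 1 to compound 3, and the step that the two limits leave unreadable from compound 2 to compound 3 is no better. All three compounds sit at the limit of > 100000 nM in this assay, at which 3 of the 3 values shown sit, so none of these steps can be read as a size or a direction. Compound 4 `O=C(c1cccc(/C=C2\CC(=O)N(c3ccccc3)C2=O)c1)N1CCCC1` differs from compound 1 at another place entirely: pyrrolidin-1-yl in place of (4-methoxyphenyl)amino on a carbonyl carbon. Going by the values given here, none of the measured steps touches this carbonyl carbon, and none has a readable size, so there is no measured step to lean on; the only guide is that every compound so far reaches the limit. Compound 4 is therefore expected to sit near 100000 nM, within an estimated range from 30000 nM to 300000 nM, which would mean an expected step of a number no higher from compound 1 to compound 4 (the limit leaves the size open).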

Compound 4, half-maximal inhibitory concentration: > 100000 nM
Compound 4: no number, only a limit; the forecaster's own chance of this, stated with the estimate: 75%; the middle value lies on the limit itself.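

Compound 4, like compound 1, gives only a limit, so no step between these two compounds can be read, and all the compounds share that same limit: the limit of > 100000 nM in this assay, at which 4 of the 4 values shown sit.

The compounds shown leave open at what concentration any of them would reach half-maximal inhibition in this assay, and so how much any of these changes matters there.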